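From methyl to methoxy on compound 1

The compounds below may be only part of what the source reports. "The series", "measured", "known", "first", "only" and "open" are said of these compounds alone.

Values from an in vivo ADME assay on the whole organism for pharmacokinetics, with Canis familiaris (Canis lupus familiaris) as the target, at a dose of 0.6 mg/kg; a higher number here means faster removal of the compound, a lower number slower removal:
- compound 1 `Cc1ccc([C@H](C(=O)N(C)C)N2C(=O)[C@@H](C3Cc4ccccc4C3)NC(=O)[C@H]2CC(C)C)cn1`: 6 mL/min/kg
- compound 2 `CC[C@H](C)[C@@H]1C(=O)N[C@H](C2Cc3ccccc3C2)C(=O)N1[C@@H](C(=O)N(C)C)c1cnc(C)cc1C`: 12 mL/min/kg
- compound 3 `CCC(CC)[C@@H]1C(=O)N[C@H](C2Cc3ccccc3C2)C(=O)N1[C@@H](C(=O)N(C)C)c1ccc(C)nc1`: 19 mL/min/kg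

Compound 1 shares the low end of this set with compound 2, the two lying within the scatter of each other. For the measured compounds named here, the one measured single-place step is a 3.2-fold higher number from compound 1 to compound 3 (0.50 log units; beyond the scatter). Going by the values given here, it concerns a saturated ring carbon, so it offers only a rough sense of size, and no measured step covers the aromatic position. Compound 4 `COc1ccc([C@H](C(=O)N(C)C)N2C(=O)[C@@H](C3Cc4ccccc4C3)NC(=O)[C@H]2CC(C)C)cn1` keeps the core of compound 1 and has methoxy in place of methyl on an aromatic carbon. The expected change in this assay is small and upward, not beyond the scatter: a 1.5-fold higher number from compound 1 to compound 4 (0.18 log units; within the scatter). For compound 4 the estimated clearance is 9 mL/min/kg, with an expected range of 4 mL/min/kg to 20 mL/min/kg.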

Compound 4, clearance: 8 mL/min/kg
Compound 4: middle estimate off by 1.1-fold (0.05 log units), on the high side; the range from low to high includes it.
By their numbers in this assay, from the lowest: compounds 1, 4, 2 and 3 (each within the scatter of the next, the first and the last beyond it).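

For the compounds shown here, at the aromatic carbon next to the ring nitrogen, methoxy in place of methyl gives a 1.3-fold higher number from compound 1 to compound 4 (0.12 log units; within the scatter) in this assay and is the first measured step at this position. Here the two groups cannot be told apart, whereas the step on the saturated ring carbon lies beyond the scatter (a 3.2-fold higher number from compound 1 to compound 3 (0.50 log units; beyond the scatter)). Nothing measured here offers an explanation for this result.

On these data alone, whether ethoxy or an amine at this carbon would stay as close to methyl remains open. So does whether methoxy would behave alike on the cores of compound 2 and compound 3.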